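Alkenyl to Isopropyl on the Shared Core: an Expected Outcome

The source may hold more compounds than are shown below. What is called first, only, known or untested is meant among the compounds shown, and "the series" means these compounds.

Compound 1 `CC(C)=Cc1c(-c2ccccc2)sc(C(C)C)c1/C=C/[C@@H](O)C[C@@H](O)CC(=O)O`: 1000 nM
Compound 2 `CC(C)c1sc(-c2ccccc2)c(-c2ccc(F)cc2)c1/C=C/[C@@H](O)C[C@@H](O)CC(=O)O`: 4.4 nM
Compound 3 `CC(C)=Cc1sc(C(C)C)c(/C=C/[C@@H](O)C[C@@H](O)CC(=O)O)c1-c1ccc(F)cc1`: 15 nM

Of the compounds shown here, three sharing one core have been measured in an assay on microsomes for inhibition of 3-hydroxy-3-methylglutaryl-coenzyme A reductase (Rattus norvegicus); on this read-out higher numbers stand for weaker inhibition and lower numbers for stronger inhibition. Compound 3 stands second highest of the three numbers; its nearest neighbour is compound 2, and the furthest is compound 1. The measured steps are a 230-fold lower number from compound 1 to compound 2 (2.36 log units; beyond the scatter) and a 3.4-fold higher number from compound 2 to compound 3 (0.53 log units; beyond the scatter).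

Compound 4 `CC(C)c1sc(C(C)C)c(-c2ccc(F)cc2)c1/C=C/[C@@H](O)C[C@@H](O)CC(=O)O` has not yet been measured. It differs from compound 3 by isopropyl in place of 2-methylprop-1-en-1-yl on an aromatic carbon. Among the measured compounds shown here, the only measured step that touches this position of the ring is the one from compound 2 to compound 3, where the 2-methylprop-1-en-1-yl group entered in place of phenyl with a modest rise in the number. The step from compound 1 to compound 2 concerns another position and bears on it only loosely. For the measured compounds named here, no measured compound carries isopropyl at this position, so the direction of the step is open; the author expects compound 4 to show a step of a 1.3-fold higher number from compound 3 to compound 4 (0.12 log units; within the scatter), small and perhaps within the scatter. The author's estimate for compound 4 in this assay is therefore 20 nM, with a range from 5 nM to 80 nM.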

Compound 4, half-maximal inhibitory concentration: 26 nM
Compound 4: middle estimate off by 1.3-fold (0.11 log units), on the low side; low and high end bracket the measured number.
By their numbers in this assay, from the lowest: compound 2; then compounds 3 and 4 (each within the scatter of the next); then compound 1.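

In this assay, the position next to the ring sulfur now carries three measured groups, and isopropyl and 2-methylprop-1-en-1-yl cannot be told apart there, since the exchange gives a 1.7-fold higher number from compound 3 to compound 4 (0.24 log units; within the scatter). Losing one carbon and the double bond outside aromatic rings therefore leaves the number within the scatter, whereas both groups without a ring stand apart from phenyl, with a 5.9-fold higher number from compound 2 to compound 4 (0.77 log units; beyond the scatter) alongside a 3.4-fold higher number from compound 2 to compound 3 (0.53 log units; beyond the scatter). Nothing available gives a reason for these numbers.

From the compounds shown here alone, whether a methyl group, an amine or a longer alkyl chain at this position would fall with phenyl or with the two groups without a ring remains open. Also open, going by these compounds, is whether a ring other than phenyl would match phenyl here.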